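Swapping a nitrile-bearing tail for a carboxylic acid

The compounds below may be only part of what the source reports. "The series", "measured", "known", "first", "only" and "open" are said of these compounds alone.

compound 1, `CCc1cc(C(C)=O)c(O)cc1OCCCCCCCC(C)(C)C#N`: 29%
compound 2, `CC(=O)c1cc(C(C)(C)C)c(OCCCCCC(C)(C)C#N)cc1O`: 2%
compound 3, `C=CCc1cc(C(C)=O)c(O)cc1OCCCCCCC`: 8%

In an assay on isolated protein for binding affinity to leukotriene B4 receptor 1 (Homo sapiens), tested at 1 uM (a higher number here means more inhibition at the concentration tested (going by the name of the read-out), a lower number less inhibition), compound 1 gives 29%, the highest of the three numbers shown; compound 3 lies beyond the scatter below it, and compound 2 further below still. Compound 4, `CCc1cc(C(C)=O)c(O)cc1OCCCCCCC(=O)O`, is not yet measured and differs from compound 1 in a single place: carboxy in place of 2-cyano-2-methylpropyl on a saturated chain carbon, six bonds along the chain from an oxygen on an aromatic ring. For the measured compounds named here, no pair of measured compounds shows this same change, so there is no measured step to lean on. The change is expected to produce a step of a number 1 percentage points higher from compound 1 to compound 4 (within the scatter), which would stay within the usual scatter, with no clear direction either way. Compound 4 is therefore estimated at 30%, within a range from 5% to 60%.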

Compound 4, a percentage reported as inhibition, at one concentration (the size of the read-out at that concentration, not a potency): 38%
Estimate against measurement, compound 4: 8 percentage points below, and the stated range covers the measured number.
By their numbers in this assay, from the lowest: compounds 2 and 3 (each within the scatter of the next); then compounds 1 and 4 (each within the scatter of the next).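

Putting carboxy in place of 2-cyano-2-methylpropyl gives a number 9 percentage points higher from compound 1 to compound 4 (within the scatter) in this assay. At this place on the chain, then, the nitrile end is not needed to keep the reading, and a smaller group carrying a hydrogen-bond donor serves as well within the scatter. No measurement shown here explains why the two groups read alike.

As far as these compounds go, it remains open whether an amine or a methyl ester at this place would read the same. Also open, from the compounds shown here alone, is whether carboxy would behave this way on the cores of compound 2 and compound 3.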